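Cyclobutane acid thioethers: amino replaced by methoxymethyl

This account rests on a few compounds, and the source may have more. Where it says the series, first, only, none or still open, it means among the compounds named here.

compound 1 `O=C(O)C1(Sc2ccnc3ccncc23)CCC1`: 1930 nM
compound 2 `Nc1ccc2nccc(SC3(C(=O)O)CCC3)c2c1`: 1790 nM

In an assay on HEK293 cells for inhibition of solute carrier family 22 member 12 (Homo sapiens), read by scintillation counting, with a stated time of 12 min (a lower number here means a stronger inhibitor, a higher number a weaker inhibitor), compound 2 gives the lowest of the two numbers, yet compound 1 lies within the scatter of it, so no order between the two can be read. Compound 3 `COCc1ccc2nccc(SC3(C(=O)O)CCC3)c2c1` is not yet measured; it carries methoxymethyl in place of amino on an aromatic carbon. For the measured compounds named here, no single-point step between measured compounds is known, so the size of this change cannot be read from the series; a step of about the scatter, in either direction, is expected. Compound 3 is estimated at 2500 nM, with a range of 900 nM to 7000 nM. The expected step is a 1.4-fold higher number from compound 2 to compound 3 (0.15 log units; within the scatter).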

Compound 3, half-maximal inhibitory concentration: 198 nM
For compound 3 the middle estimate is 13-fold (1.10 log units) above the measured one; the measured number lies below the stated range.
By their numbers in this assay, from the lowest: compound 3; then compounds 2 and 1 (each within the scatter of the next).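

In this assay, this position, on the six-membered aromatic ring of carbon only, proves sensitive to its substituent: methoxymethyl in place of amino gives a 9.0-fold lower number from compound 2 to compound 3 (0.96 log units; beyond the scatter). For the compounds shown here, this is the only single-place step so far, and it removes the hydrogen-bond donor of the amino group while the hydrogen-bond acceptor count stays the same. No measurement shown explains the size of this step. As far as these compounds go, it remains open whether the ether oxygen or the longer chain carries the effect. An ethyl, methoxy or hydroxymethyl group at this place would help separate the two.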